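From benzyl to 2-(dimethylamino)ethyl on the amine nitrogen

A few compounds are considered here, and "the series" means these few. Any claim that something is new, unique, unknown or untested is made for them only; others in the source may bear on it.

Measured so far in a functional assay on the whole organism for positive allosteric modulation, with Mus musculus as the target; a lower number here means that less compound is needed, a higher number that more compound is needed for the effect:
compound 1 (`C=CCN(C)C1CCCC1N(C(=O)CC)c1ccc(Cl)c(Cl)c1`) gives 0.2 mg/kg
compound 2 (`CCC(=O)N(c1ccc(Cl)c(Cl)c1)C1CCCC1N(C)Cc1ccccc1`) gives 0.2 mg/kg

Level with compound 1, compound 2 stands at 0.2 mg/kg and has no other measured neighbour. Compound 3 (`CCC(=O)N(c1ccc(Cl)c(Cl)c1)C1CCCC1N(C)CCN(C)C`) differs from it as follows: (dimethylamino)methyl in place of phenyl on a saturated chain carbon bound to an amine nitrogen (the same difference reads benzyl to 2-(dimethylamino)ethyl). Among the compounds with values here, one measured step bears on this place, a swap of vinyl for phenyl on a saturated chain carbon bound to an amine nitrogen, and it shows no change at the digits printed from compound 1 to compound 2 (within the scatter) in this assay on that swap. Neither vinyl nor phenyl contains the nitrogen that enters here, so that step is only a loose guide. The expected step is a 2.5-fold higher number from compound 2 to compound 3 (0.40 log units; beyond the scatter) in this assay, a modest move toward a higher dose, and it is uncertain. Compound 3 is estimated at 0.5 mg/kg (expected range 0.1 mg/kg to 2.5 mg/kg).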

Compound 3, dose for half-maximal effect: 0.8 mg/kg
Estimate against measurement, compound 3: 1.6-fold (0.20 log units) below; low and high end bracket the measured number.
By their numbers in this assay, from the lowest: compounds 1 and 2 (each within the scatter of the next); then compound 3.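

In this assay this place, on a saturated chain carbon bound to an amine nitrogen, turns out to respond to what is put there: (dimethylamino)methyl brings a 4.0-fold higher number from compound 2 to compound 3 (0.60 log units; beyond the scatter), and against vinyl it brings a 4.0-fold higher number from compound 1 to compound 3 (0.60 log units; beyond the scatter), whereas the swap of vinyl for phenyl had stayed within the scatter. The step is modest, and compound 3 is the only compound shown with a second amine nitrogen, so one compound supports no general pattern. Nothing measured here speaks to the reason for this rise.

Since phenyl leaves as the dimethylamino group enters, the compounds shown do not separate the loss of the ring from the arrival of the nitrogen. On these data alone, it remains open whether a plain propyl chain, a 2-methoxyethyl group or a longer 3-(dimethylamino)propyl chain would sit nearer compound 3 or compound 2.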